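A few compounds are considered here, and "the series" means these few. Any claim that something is new, unique, unknown or untested is made for them only; others in the source may bear on it.

Going by the values given here, compound 3 `ClCc1ccccc1Cn1cnc2ncnc(Cl)c21` stands second highest of the three numbers so far in a functional assay on SF-539 cells (Homo sapiens) for cytotoxicity, read by sulforhodamine B assay, with a stated time of 48 h (a lower number here means a stronger inhibitor of growth, a higher number a weaker inhibitor of growth), with compound 3 giving 5010 nM. Compound 1 `ClCc1ccc(Cn2cnc3c(Cl)ncnc32)cc1` gives 1170 nM in this assay, and compound 2 `ClCc1cccc(Cn2cnc3c(Cl)nc(Cl)nc32)c1` gives 14100 nM; these two differ from compound 3 in more than one place, so their values are read only as a spread. Compound 4 `ClCc1ccccc1Cn1cnc2nc(Cl)nc(Cl)c21` differs from compound 3 by chloro in place of hydrogen on an aromatic carbon. Among the compounds with values here, no measured pair isolates this change. Within the data shown here, compound 2, the one compound already carrying two chloro groups on the core, has the highest number of the three, so the step from compound 3 to compound 4 is expected to raise the number by a 2.0-fold higher number from compound 3 to compound 4 (0.30 log units; within the scatter), beyond the scatter. Compound 4 is thus expected to give 10000 nM, within 3500 nM to 28000 nM.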

Compound 4, concentration for total growth inhibition: 4260 nM
Compound 4: middle estimate off by 2.3-fold (0.37 log units), on the high side; low and high end bracket the measured number.
By their numbers in this assay, from the lowest: compound 1; then compounds 4 and 3 (each within the scatter of the next); then compound 2.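

In this assay, going by these compounds alone, chloro in place of hydrogen on an aromatic carbon, between two ring nitrogen atoms, gives a 1.2-fold lower number from compound 3 to compound 4 (0.07 log units; within the scatter), the first step that isolates this position. With the rest of compound 3 unchanged, a chloro group here therefore leaves the number within the scatter. No measurement on hand explains this result.

As far as these compounds go, whether an amine or a methoxy group at this position would also stay within the scatter remains open. So does whether chloro there gives the same step with the chloromethyl group placed as in compound 1.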